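The source may hold more compounds than are shown below. What is called first, only, known or untested is meant among the compounds shown, and "the series" means these compounds.

Compound 1 `N#CC1=C(NCN2CCCC2)N(c2ccccc2)C(=O)N2CCCCC(N3CCCC3)C12`: 26.6%
Compound 2 `N#CC1=C(/N=C/Nc2ccc([N+](=O)[O-])cc2)N(c2ccccc2)C(=O)N2CCCCC(N3CCCC3)C12`: 41.5%
Compound 3 `N#CC1=C(/N=C/Nc2ccccc2)N(c2ccccc2)C(=O)N2CCCCC(N3CCCC3)C12`: 47.5%

In a functional assay on the whole organism (strain albino) for inhibition, with Rattus norvegicus as the target, read by paw edema, with stated times of 1 h and 2 h, at a dose of 20 mmol/kg by the intraperitoneal route (on this read-out higher numbers stand for more inhibition at the one dose given (going by the name of the read-out) and lower numbers for less inhibition), compound 3 stands highest of the three numbers. The nearest number is that of compound 2, and the step of a number 6 percentage points higher from compound 2 to compound 3 (within the scatter) lies within the scatter, so the two cannot be ordered. The furthest is that of compound 1, and the step of a number 20.9 percentage points higher from compound 1 to compound 3 (beyond the scatter) lies beyond the scatter.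

Compound 4 `N#CC1=C(NCC(=O)N2CCCCC2)N(c2ccccc2)C(=O)N2CCCCC(N3CCCC3)C12` has not yet been measured. It differs from compound 3 in one place: a group of 10 heavy atoms (7 carbon, 2 nitrogen, 1 oxygen; one six-membered non-aromatic ring with 1 hetero atom) in place of a group of 9 heavy atoms (7 carbon, 2 nitrogen; one six-membered aromatic ring of carbon only), on a double-bonded ring carbon

For the measured compounds named here, two measured steps bear on this change. In both a number 14.9 percentage points higher from compound 1 to compound 2 (beyond the scatter) and a number 20.9 percentage points higher from compound 1 to compound 3 (beyond the scatter) a group holding a six-membered aromatic ring of carbon only replaced a group holding a five-membered non-aromatic ring with one hetero atom, and each time the number rose by a modest amount. Compound 4 goes the opposite way: the aromatic ring leaves, and a group with a six-membered non-aromatic ring with one hetero atom enters. A modest fall is therefore expected, a number 15.5 percentage points lower from compound 3 to compound 4 (beyond the scatter), placing compound 4 nearer to compound 1 than to compound 3. Compound 4 is estimated at 32%, with a range from 20% to 45%.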

Compound 4, a percentage reported as inhibition, in the whole organism at one dose (the size of the read-out at that dose, not a potency): 46.1%
Compound 4: middle estimate off by 14.1 percentage points, on the low side, outside the stated range (above it).
By their numbers in this assay, from the lowest: compound 1; then compounds 2, 4 and 3 (each within the scatter of the next).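

In this assay the step of a number 1.4 percentage points lower from compound 3 to compound 4 (within the scatter) and the step of a number 4.6 percentage points higher from compound 2 to compound 4 (within the scatter) show that, on this double-bonded ring carbon, a group with a six-membered non-aromatic ring can read like the two groups holding a six-membered aromatic ring of carbon only, so the rise over compound 1 does not depend on that aromatic ring. The step of a number 19.5 percentage points higher from compound 1 to compound 4 (beyond the scatter) shows that a change confined to the end of the chain, (piperidin-1-yl)carbonyl in place of pyrrolidin-1-yl on a saturated chain carbon bound to an amine nitrogen, is enough for a rise of this kind. No measured evidence is at hand on why these different groups give such similar numbers.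

This change swaps in a carbonyl and a larger ring together, so the compounds shown cannot say which of the two matters; pyrrolidin-1-ylcarbonyl or plain piperidin-1-yl on the same chain would separate them. On these data alone, how a morpholin-4-ylcarbonyl group or a carboxylic acid at the end of this chain would read also remains open.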